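The source may report more compounds than this note shows. Statements on the series, on what has been measured and on what is new or still open speak of the compounds shown alone.

Working notes on the series, read in an in vitro ADME assay on microsomes from liver (Homo sapiens) for metabolic stability, tested at 5 uM; on this read-out higher numbers stand for a longer-lived compound and lower numbers for a shorter-lived compound. Compound 1 (`CC(C)CCn1nc(-c2cccs2)c(O)c(C2=NS(=O)(=O)c3cc(S(C)(=O)=O)ccc3N2)c1=O`) gives 0.0933 h and compound 2 (`CC(C)CCn1nc(-c2cccs2)c(O)c(C2=NS(=O)(=O)c3cc(S(=O)(=O)N(C)C)ccc3N2)c1=O`) gives 0.183 h. Compound 3 (`CC(C)CCn1nc(C2CCCCC2)c(O)c(C2=NS(=O)(=O)c3cc(NS(C)(=O)=O)ccc3N2)c1=O`) gives 0.117 h, which lies within the scatter of both compound 1 and compound 2.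

Compound 4 (`CC(C)CCn1nc(CC(C)C)c(O)c(C2=NS(=O)(=O)c3cc(NS(C)(=O)=O)ccc3N2)c1=O`) is not yet measured. It differs from compound 3 as follows: isobutyl in place of cyclohexyl on an aromatic carbon. In short, isobutyl stands in place of cyclohexyl on an aromatic carbon.

Among the measured compounds shown here, the only measured single-place step is a 2.0-fold higher number from compound 1 to compound 2 (0.29 log units; within the scatter), with dimethylamino in place of methyl on a sulfonyl sulfur. That step lies within the scatter and concerns a different place, so it bears only indirectly. For the measured compounds named here, no measured step covers the aromatic carbon that changes here. All three values in this assay sit within the scatter of one another, so no step beyond the scatter is expected. The expected move is a 1.1-fold higher number from compound 3 to compound 4 (0.05 log units; within the scatter), which is small and of uncertain direction. For compound 4 the estimate is 0.13 h, with an expected range of 0.065 h to 0.26 h.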

Compound 4, half-life: 0.123 h
Compound 4: middle estimate off by 1.1-fold (0.02 log units), on the high side, and the stated range covers the measured number.
By their numbers in this assay, from the lowest: compounds 1, 3, 4 and 2 (each within the scatter of the next).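

At this position, an aromatic carbon next to the ring nitrogen, isobutyl in place of cyclohexyl gives a 1.1-fold higher number from compound 3 to compound 4 (0.02 log units; within the scatter) in this assay, the only step shown at this place. The open chain of four carbons and the six-membered carbon ring therefore cannot be told apart on this read-out, at least with the rest of compound 3 held constant. No supporting measurement bears on this result, so nothing can be said about what lies behind it.

On these data alone, whether an amine, a carboxylic acid or a phenyl ring on this carbon would give a step beyond the scatter remains open. As far as these compounds go, it is also open whether the same exchange would read alike with another group on the sulfonyl sulfur, since compound 1 and compound 2 differ from compound 3 and compound 4 in more than one place.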